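This account rests on a few compounds, and the source may have more. Where it says the series, first, only, none or still open, it means among the compounds named here.

Working notes on a small set built on one shared core. Compound 1 `CCOC(=O)C(=Cc1c(-c2ccccc2)[nH]c2ccccc12)C(=O)OCC` and compound 2 `O=C(/C(=C\c1c(-c2ccccc2)[nH]c2ccccc12)S(=O)(=O)c1ccccc1)c1ccccc1` have both been run in a functional assay on ACHN cells (Homo sapiens) for inhibition, read by sulforhodamine B assay, with a stated time of 48 h; a lower number here means a stronger inhibitor of growth, a higher number a weaker inhibitor of growth. In this assay compound 1 gives 4400 nM, and in this assay compound 2 gives 6700 nM; the two numbers lie within the usual scatter of each other, so neither stands apart on the data so far. Compound 3 `CC(=O)/C(=C\c1c(-c2ccccc2)[nH]c2ccccc12)S(=O)(=O)c1ccccc1` remains to be measured in this assay. Relative to compound 2 it carries methyl in place of phenyl on a carbonyl carbon. Going by the values given here, no measured pair shows this change, so no step beyond the scatter is expected in either direction. Compound 3 is estimated at 7000 nM (range 2500 nM to 20000 nM) in this assay, an expected step of a 1.0-fold higher number from compound 2 to compound 3 (0.02 log units; within the scatter).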

Compound 3, concentration for 50% growth inhibition: 1800 nM
The estimate for compound 3 lay 3.9-fold (0.59 log units) above the measured number, and the stated range ends above it.
By their numbers in this assay, from the lowest: compound 3; then compounds 1 and 2 (each within the scatter of the next).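

Going by these compounds alone, on the carbonyl carbon, the change from benzoyl to acetyl gives the first step beyond the scatter: in this assay there is a 3.7-fold lower number from compound 2 to compound 3 (0.57 log units; beyond the scatter) with methyl in place of phenyl. The phenyl at this position is therefore not needed for growth inhibition, at least in this single pair. Nothing measured here bears on why the number falls.

On these data alone, whether the step would hold with an ethyl or a longer chain on this carbonyl carbon remains open. An amine at the same place, giving an amide, is also untested in the compounds shown.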